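This account rests on a few compounds, and the source may have more. Where it says the series, first, only, none or still open, it means among the compounds named here.

Measured in a functional assay on MV4-11 cells (Homo sapiens) for antiproliferative activity, read by resazurin assay, with a stated time of 72 h; a higher number here means a weaker inhibitor of growth, a lower number a stronger inhibitor of growth:

- Compound 1 `CC(=O)N1CCN(c2ccc(Nc3nccc(-c4c[nH]c5cccnc45)n3)cc2)CC1`: 420 nM
- Compound 2 `CC(=O)N1CCN(c2ccc(Nc3nccc(-c4c[nH]c5ncccc45)n3)cc2)CC1`: < 1 nM (a limit of the assay, not a number)

Compound 2 stands at the low end of what this assay can report: the limit of < 1 nM in this assay, at which 1 of the 2 values shown sits. Its true number is therefore unknown.

Compound 3 `CC(=O)N1CCN(c2ccc(Nc3nccc(-c4cn(C)c5ncccc45)n3)cc2)CC1` keeps everything in compound 2 except for one small change, methyl in place of hydrogen on an aromatic nitrogen. Among the compounds with values here, no measured step tests this change directly. Within the data shown here, only one step bears on it, and only indirectly: an at least 420-fold lower number from compound 1 to compound 2 (2.62 log units; beyond the scatter). That step was large and lay beyond the scatter. It came from a change inside the core, and it left this hydrogen in place. It shows that, for these two compounds, the number can respond strongly to a change in the core, so a sizeable effect from the new methyl seems possible.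

Since compound 2 sits at a limit, any visible move is likely to be upward, towards weaker growth inhibition. The expected move is an at least 30-fold higher number from compound 2 to compound 3 (1.47 log units; beyond the scatter), an estimate with wide uncertainty. For compound 3 the estimated value is 30 nM, with an expected range of 2 nM to 500 nM.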

Compound 3, concentration for 50% growth inhibition: 74 nM
Compound 3: middle estimate off by 2.5-fold (0.39 log units), on the low side; low and high end bracket the measured number.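

In this assay, the hydrogen on the aromatic nitrogen of the five-membered ring is now tested directly: putting a methyl there, a change of just one heavy atom, gives an at least 74-fold higher number from compound 2 to compound 3 (1.86 log units; beyond the scatter), so this position is highly sensitive to change. On these data alone, compound 2 is recorded at a limit and not as a number, so this step gives only a minimum size, and the full size stays unknown: the limit of < 1 nM in this assay, at which 1 of the 3 values shown sits. The methyl does not cancel the whole gain from the change in the core, since there is still a 5.7-fold lower number from compound 1 to compound 3 (0.75 log units; beyond the scatter), a modest step beyond the scatter.

As far as these compounds go, what remains open is whether the drop comes from losing the hydrogen or from the space the methyl fills, and an ethyl group, a longer chain or a hydroxyethyl group on this nitrogen would help to tell these apart. The compounds shown also leave open how the same methyl would act on the core of compound 1, and whether a group other than methyl could be tolerated here at all.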